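Moving the hydroxycarbamoyl group onto an ethyl chain

The source may report more compounds than this note shows. Statements on the series, on what has been measured and on what is new or still open speak of the compounds shown alone.

Measured so far in a functional assay on Jurkat cells (Homo sapiens) for cytotoxicity, read by MTT assay, with a stated time of 72 h (a higher number here means a weaker inhibitor, a lower number a stronger inhibitor), for three compounds
compound 1 `O=C(Nc1ccc(Cl)cc1)Nc1ccc(C(=O)NO)cc1` gives 1060 nM
compound 2 `COc1ccc(NC(=O)Nc2ccc(C(=O)NO)cc2)cc1` gives 8030 nM
compound 3 `O=C(Nc1ccc(C(=O)NO)cc1)Nc1ccc([N+](=O)[O-])cc1` gives 12700 nM

Compound 1 has the lowest number of the three in this assay and is the strongest inhibitor among them, with both of its steps beyond the scatter. Methoxy in place of its chloro gives a modest step (a 7.6-fold higher number from compound 1 to compound 2 (0.88 log units; beyond the scatter)) and nitro in place of its chloro gives a large one (a 12-fold higher number from compound 1 to compound 3 (1.08 log units; beyond the scatter)). The remaining exchange, nitro in place of methoxy, stays within the scatter (a 1.6-fold higher number from compound 2 to compound 3 (0.20 log units; within the scatter)).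

Compound 4 `O=C(CCc1ccc(NC(=O)Nc2ccc(Cl)cc2)cc1)NO` keeps the chloro of compound 1 and differs elsewhere (2-(hydroxycarbamoyl)ethyl in place of hydroxycarbamoyl on an aromatic carbon), with 2-(hydroxycarbamoyl)ethyl in place of hydroxycarbamoyl on an aromatic carbon. For the measured compounds named here, none of the measured steps touches this site. They bear on it only indirectly, showing that a single exchange in this small set can reach a large step. Going by the values given here, no measured compound carries the new group, so the data give no direction. The estimated step is small (a 1.2-fold lower number from compound 1 to compound 4 (0.07 log units; within the scatter)) and no shift beyond the scatter is expected, though with wide uncertainty on either side. Compound 4 is expected near 900 nM within a range from 200 nM to 4000 nM as an estimate.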

Compound 4, half-maximal inhibitory concentration: 410 nM
Beside the measured number, compound 4's estimate is 2.2-fold (0.34 log units) above it; the measured number falls inside the stated range.
By their numbers in this assay, from the lowest: compound 4; then compound 1; then compounds 2 and 3 (each within the scatter of the next).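

For the compounds shown here, every step measured before compound 4 concerned the chloro site, so the earlier compounds said nothing about the hydroxycarbamoyl position on the aromatic carbon para to a large group. In this assay, 2-(hydroxycarbamoyl)ethyl in place of hydroxycarbamoyl, with the chloro kept, gives a 2.6-fold lower number from compound 1 to compound 4 (0.41 log units; beyond the scatter) and so shows that this position also responds to change, and that a group of 6 heavy atoms in place of one of 4 lowers the number rather than raising it. Nothing available accounts for this modest step, so its origin cannot be stated.

The compounds shown leave open whether the number keeps falling with a longer chain, such as a 3-(hydroxycarbamoyl)propyl group, or whether the ethyl length is already enough, and what a carboxylic acid would do in place of the hydroxycarbamoyl end. Going by these compounds, the ethyl chain also appears here only with the chloro, so it remains open whether the methoxy or nitro exchanges would give steps of similar size on that chain.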